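Selenium for sulfur on a quinazoline-type core: a second trial

The compounds below may be only part of what the source reports. "The series", "measured", "known", "first", "only" and "open" are said of these compounds alone.

Three compounds share a core that is measured in a functional assay on MCF7 cells (Homo sapiens) for cytotoxicity, read by MTT assay, with a stated time of 72 h; a higher number here means a weaker inhibitor of growth, a lower number a stronger inhibitor of growth. Compound 2, with structure `COc1ccc(CNc2nc(SC)nc3ccccc23)cc1`, gives 30900 nM. Compound 1, with structure `COc1ccc(CNc2nc([Se]C)nc3ccccc23)cc1`, gives 42200 nM. Compound 3, with structure `CSc1ccc(CNc2nc(SC)nc3ccccc23)cc1`, gives 47300 nM. The three numbers sit close together, and none of the steps between them exceeds the usual scatter.

Compound 1 is obtained from compound 2 by the change (a group of 2 heavy atoms (1 carbon, 1 selenium; no ring) in place of a group of 2 heavy atoms (1 carbon, 1 sulfur; no ring), on an aromatic carbon), and the step is a 1.4-fold higher number from compound 2 to compound 1 (0.14 log units; within the scatter). Compound 3 is obtained from compound 2 by the change (methylsulfanyl in place of methoxy on an aromatic carbon), and the step is a 1.5-fold higher number from compound 2 to compound 3 (0.18 log units; within the scatter).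

Compound 4, with structure `CSc1ccc(CNc2nc([Se]C)nc3ccccc23)cc1`, has not yet been measured. It is obtained from compound 3 by the change (a group of 2 heavy atoms (1 carbon, 1 selenium; no ring) in place of a group of 2 heavy atoms (1 carbon, 1 sulfur; no ring), on an aromatic carbon), the same change that turns compound 2 into compound 1, carried out on the same place of the core. The two cores differ by the change from compound 2 to compound 3, as given above.

Because the earlier step of a 1.4-fold higher number from compound 2 to compound 1 (0.14 log units; within the scatter) was small, the step from compound 3 to compound 4 in this assay is expected to be about as small, with a 1.3-fold higher number from compound 3 to compound 4 (0.10 log units; within the scatter) as the estimate. On that basis compound 4 is expected to give about 60000 nM in this assay, with a plausible range from 30000 nM to 120000 nM. This expectation rests on a single prior example of the change and on a set of three compounds only.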

Compound 4, concentration for 50% growth inhibition: 54100 nM
For compound 4 the middle estimate is 1.1-fold (0.04 log units) above the measured one, within the range that was stated.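

In this assay, putting the selenium-bearing group in place of methylsulfanyl on the aromatic carbon between two ring nitrogen atoms gives a 1.1-fold higher number from compound 3 to compound 4 (0.06 log units; within the scatter), and this step matches the earlier one on the core carrying methoxy: the same change on two cores in this assay, a 1.4-fold higher number (0.14 log units; within the scatter) from compound 2 to compound 1 and a 1.1-fold higher number (0.06 log units; within the scatter) from compound 3 to compound 4, 1.2-fold (0.08 log units) apart, within the scatter of two such steps. Read the other way, methylsulfanyl in place of methoxy gives a 1.3-fold higher number from compound 1 to compound 4 (0.11 log units; within the scatter) on the selenium-bearing core, and this agrees with the same change on the sulfur-bearing core: the same change on two cores in this assay, a 1.5-fold higher number (0.18 log units; within the scatter) from compound 2 to compound 3 and a 1.3-fold higher number (0.11 log units; within the scatter) from compound 1 to compound 4, 1.2-fold (0.08 log units) apart, within the scatter of two such steps. Going by these compounds alone, both changes therefore carry from one core to the other without a difference that can be told from noise, but every step here lies within the scatter, so the agreement shows only that neither change moves the number measurably on these cores; it does not show that a change with a large effect would carry over in the same way, and each change rests on just two cores.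

On these data alone, it remains open whether a longer chain or an amine in place of methylsulfanyl at that same carbon would move the number beyond the scatter. As far as these compounds go, it also remains open whether the selenium exchange would stay as small with a hydroxyl or a carboxylic acid in place of methoxy.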